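Replacing the pyridin-2-yl group in the series

A few compounds are considered here, and "the series" means these few. Any claim that something is new, unique, unknown or untested is made for them only; others in the source may bear on it.

Among the compounds with values here, in a physicochemical assay for lipophilicity, at pH 7.4 (on this read-out lower numbers stand for lower lipophilicity and higher numbers for higher lipophilicity), compound 2 `CN(C)C(=O)C1CCN(c2cnccc2-c2ccccn2)CC1` gives 1.2 as the lower of the two numbers so far. Compound 1 `CN(C)C(=O)C1CCN(c2cncnc2-c2ccc(F)cc2)CC1` gives 1.9 and stands beyond the scatter from it. Compound 3 `Cc1cnc(-c2ccncc2N2CCC(C(=O)N(C)C)CC2)s1` differs from compound 2 by 5-methyl-1,3-thiazol-2-yl in place of pyridin-2-yl on an aromatic carbon with 5-methyl-1,3-thiazol-2-yl in place of pyridin-2-yl on an aromatic carbon. Within the data shown here, no measured pair shows this exchange, so the expectation rests on the structural change alone. An upward step is expected in this assay and the estimated size a number 0.60 log units higher from compound 2 to compound 3 (beyond the scatter) lies beyond the scatter. For compound 3 the estimate is 1.8 with an expected range from 1.4 to 2.2 on this read-out.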

Compound 3, distribution coefficient: 2
Beside the measured number, compound 3's estimate is 0.20 log units below it; the range from low to high includes it.
By their numbers in this assay, from the lowest: compound 2; then compounds 1 and 3 (each within the scatter of the next).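

Within the data shown here, on the aromatic carbon opposite the ring nitrogen, ortho to a large group, 5-methyl-1,3-thiazol-2-yl in place of pyridin-2-yl gives a number 0.80 log units higher from compound 2 to compound 3 (beyond the scatter) in this assay, the only single-place step so far. Both groups hold 6 heavy atoms and carry no net charge, yet the step lies beyond the scatter. No measurement shown accounts for this step.

Still open, from the compounds shown here alone, is how much of the step belongs to the five-membered ring and how much to its methyl group, which the unsubstituted 1,3-thiazol-2-yl group would separate. Going by these compounds, how an amine or a carboxylic acid on this carbon would read in this assay also remains open.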